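From nitro to fluoro on a shared core

The compounds below may be only part of what the source reports. "The series", "measured", "known", "first", "only" and "open" are said of these compounds alone.

Of the compounds shown here, three built on one shared core have been measured so far in a physicochemical assay for lipophilicity, measured as octanol-water partition; on this read-out higher numbers stand for higher lipophilicity and lower numbers for lower lipophilicity. Compound 2 (`O=C(COc1cccc2ccccc12)N/N=C/c1ccc([N+](=O)[O-])cc1`) stands lowest of these at 3.97 on this scale, beyond the scatter from both others. Compound 1 (`O=C(COc1cccc2ccccc12)N/N=C/c1ccc(Br)cc1`) reads 4.81 and compound 3 (`O=C(COc1cccc2ccccc12)N/N=C/c1c(O)ccc2ccccc12`) reads 4.74 in this assay, and those two values lie within the scatter of each other.

The next compound is compound 4 (`O=C(COc1cccc2ccccc12)N/N=C/c1ccc(F)cc1`), which carries fluoro in place of nitro on an aromatic carbon. The change sits on a six-membered aromatic ring of carbon only, para to a large group. Among the compounds with values here, one measured step bears directly on it: nitro in place of bromo at that same place (a number 0.84 log units lower from compound 1 to compound 2 (beyond the scatter)), a modest step beyond the scatter. Within the data shown here, compound 3 offers no single-place step. Read in reverse, that one step has bromo at the higher number, and no measured compound yet carries fluoro. A rise from compound 2 is therefore expected, smaller than the gap that separates it from compound 1, which reads 4.81, but still of modest size. The expected step is a number 0.38 log units higher from compound 2 to compound 4 (beyond the scatter) in this assay. For compound 4 the estimated value is 4.35 within an expected range of 4 to 4.7.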

Compound 4, partition coefficient: 4.16
The estimate for compound 4 lay 0.19 log units above the measured number, and the stated range covers the measured number.
By their numbers in this assay, from the lowest: compounds 2 and 4 (each within the scatter of the next); then compounds 3 and 1 (each within the scatter of the next).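

In this assay, replacing nitro, with its 3 heavy atoms and 2 hydrogen-bond acceptors, by fluoro, with 1 heavy atom and no hydrogen-bond acceptor, gives a number 0.19 log units higher from compound 2 to compound 4 (within the scatter), so these two groups cannot be told apart at this place on the aromatic ring despite those differences in the counts. Bromo, by contrast, is separated from fluoro as well as from nitro, with a number 0.65 log units lower from compound 1 to compound 4 (beyond the scatter) alongside the earlier a number 0.84 log units lower from compound 1 to compound 2 (beyond the scatter), which leaves compound 1 apart from both compound 2 and compound 4 among these three compounds that differ in one place. No measurement among those shown explains why bromo stands apart at this place or why nitro and fluoro do not differ.

The three groups alone do not show whether a chlorine atom, a methyl group, an amine or a carboxylic acid at this place would fall with fluoro and nitro or with bromo. On these data alone, it also remains open whether the same grouping would hold if these substituents sat elsewhere on the six-membered aromatic ring.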